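From Cyclopropyl to Cyclopentyl: What to Expect

A few compounds are considered here, and "the series" means these few. Any claim that something is new, unique, unknown or untested is made for them only; others in the source may bear on it.

In an ADME assay on liver (Mus musculus) for metabolic stability, read by LC-MS, using microsomes and NADPH (on this read-out higher numbers stand for a more stable compound and lower numbers for a less stable compound), compound 3 `Cc1cc(CN(CC2CC2)[C@@H](CC(=O)O)c2ccc(Cl)cc2)ccc1OCCN1C(=O)CCC1=O` gives 87%. Compound 2 `Cc1cc(CN(CC2CC2)C(CC(=O)O)c2ccc(Cl)cc2)ccc1OCCN1C(=O)CCC1=O` gives 83%, within the scatter of compound 3, whereas compound 1 `CCCN(Cc1ccc(OCCN2C(=O)CCC2=O)c(C)c1)C(CC(=O)O)c1ccc(Cl)cc1` gives 75%, lower than compound 3 by more than the scatter.

Compound 4 `Cc1cc(CN(CC2CCCC2)[C@@H](CC(=O)O)c2ccc(Cl)cc2)ccc1OCCN1C(=O)CCC1=O` carries cyclopentyl in place of cyclopropyl on a saturated chain carbon bound to an amine nitrogen. Going by the values given here, only one measured change falls at this place, and it is a number 8 percentage points higher from compound 1 to compound 2 (within the scatter). The other measured change, a number 4 percentage points higher from compound 2 to compound 3 (within the scatter), concerns the fact that one of compounds 2 and 3 is drawn with a defined configuration and the other without, at the place where they differ and leaves this place untouched, so it offers no guide to the new ring.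

On the strength of a number 8 percentage points higher from compound 1 to compound 2 (within the scatter), the swap is expected to produce a step of modest size in this assay. Among the compounds with values here, no measurement yet covers a ring as large as cyclopentyl at this place, so the expectation is held loosely, with a lean downward and a wide range. The estimated step is a number 9 percentage points lower from compound 3 to compound 4 (within the scatter). Compound 4 is expected to give 78%, with an estimated range from 60% to 91%.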

Compound 4, percent of the compound remaining: 69%
Estimate against measurement, compound 4: 9 percentage points above; measured number inside the range.
By their numbers in this assay, from the lowest: compounds 4, 1, 2 and 3 (each within the scatter of the next, the first and the last beyond it).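

At this place, on a saturated chain carbon bound to an amine nitrogen, a number 18 percentage points lower from compound 3 to compound 4 (beyond the scatter) in this assay is the first step shown here that passes beyond the scatter, so the group carried there does matter to this read-out. The earlier change at the same place, a number 8 percentage points higher from compound 1 to compound 2 (within the scatter), had left that open, and the data now show that exchanging one saturated carbon ring for a larger one can lower the number even where the change from ethyl to cyclopropyl did not move it beyond the scatter. Nothing known about these compounds speaks to why cyclopentyl gives this result, as the one available observation concerns only a difference in drawn configuration and has no bearing on this change.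

The compounds shown leave open how the number runs with ring size at this place, and what cyclobutyl or cyclohexyl would give there. They also leave open whether a ring holding oxygen, such as tetrahydrofuranyl, or an open branched chain such as isobutyl, would follow cyclopropyl or cyclopentyl in this assay.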